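Cyanoguanidine series: phenylsulfanyl chain onto aminotriazole fragment

The source may hold more compounds than are shown below. What is called first, only, known or untested is meant among the compounds shown, and "the series" means these compounds.

Measured so far in a functional assay on Sf9 cells for antagonist activity at histamine H2 receptor (Homo sapiens), read by scintillation counting and GTPgammaS binding, with a stated time of 90 min; on this read-out lower numbers stand for lower potency and higher numbers for higher potency (the scale is a negative logarithm):
- compound 1, `Cc1nc(CCCN/C(=N\C#N)NCCSc2ccccc2)c[nH]1`; compound 1 gives < 5, a limit of the assay.
- compound 2, `N#C/N=C(\NCCCCc1cnn[nH]1)NCCSc1ccccc1`; compound 2 gives < 5, a limit of the assay.
- compound 3, `CN/C(=N/C#N)NCCCNc1nc(N)n[nH]1`; compound 3 gives < 5, a limit of the assay.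

Compound 3 therefore stands at the assay limit, with no number of its own. Among the measured compounds shown here, every value in this assay so far is of that kind: the limit of < 5 in this assay, at which 3 of the 3 values shown sit.

Compound 4, `N#C/N=C(\NCCCNc1nc(N)n[nH]1)NCCSc1ccccc1`, differs from compound 3 in one place: (phenylsulfanyl)methyl in place of hydrogen on a saturated chain carbon bound to an amine nitrogen. For the measured compounds named here, of the measured steps only one is available for comparison, and it concerns the heterocyclic end of the chain rather than the (phenylsulfanyl)methyl end: a step that the two limits leave unreadable from compound 1 to compound 2. Compounds 1 and 2 both carry the (phenylsulfanyl)methyl group that enters in compound 4, and both sit at the limit, so the group on its own has not lifted any compound of the series into the readable range. Going by the values given here, no measured step bears directly on the change from compound 3 to compound 4, and its size cannot be read from the limits.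

For compound 4 the estimate in this assay is 5, between 4.3 and 5.8. The expected step from compound 3 to compound 4 is a number no lower from compound 3 to compound 4 (the limit leaves the size open), with a substantial chance that the assay again reports only a limit.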

Compound 4, negative logarithm of the antagonist equilibrium constant: < 5
Compound 4: no number, only a limit; the forecaster's own chance of this, stated with the estimate: 60%; the middle value lies on the limit itself.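

In this assay no new step can be read, since compound 4 sits at a limit of the assay, as do compound 1, compound 2 and compound 3, and its steps from all three stay unreadable. Every value shown is of this kind: the limit of < 5 in this assay, at which 4 of the 4 values shown sit. The compounds shown leave open the actual potency of all four compounds and the size of every step among them.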